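Benzyl for cyclohexyl on the imidazole nitrogen of the series

A few compounds are considered here, and "the series" means these few. Any claim that something is new, unique, unknown or untested is made for them only; others in the source may bear on it.

Of the compounds shown here, three have been measured in a functional assay on MDA-MB-231 cells (Homo sapiens) for inhibition, read by sulforhodamine B assay, with a stated time of 48 h, tested at 10 uM; on this read-out lower numbers stand for less inhibition and higher numbers for more inhibition at the one concentration tested (going by the name of the read-out). Compound 1 `c1ccc2c(-c3cn4ccnc4c(-c4ccc5ncn(C6CCCCC6)c5c4)n3)cccc2c1` gives 20.8% in this assay. Compound 2 `c1ccc(Cn2cnc3ccc(-c4nc(-c5cccc6ccccc56)cn5ccnc45)cc32)cc1` gives 28.7% in this assay. Compound 3 `c1cn2cc(-c3ccc4c(c3)ncn4C3CCCCC3)nc(-c3ccc4ncn(C5CCCCC5)c4c3)c2n1` gives 28.9% in this assay.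

Among the measured compounds shown here, the one counted change among the measured pairs is benzyl in place of cyclohexyl on an aromatic nitrogen; it made a number 7.9 percentage points higher from compound 1 to compound 2 (within the scatter). The difference between the core of compound 1 and the core of compound 3 is not broken down here.

Compound 4 `c1ccc(Cn2cnc3ccc(-c4nc(-c5ccc6c(c5)ncn6C5CCCCC5)cn5ccnc45)cc32)cc1` is still to be measured in this assay. It differs from compound 3 by benzyl in place of cyclohexyl on an aromatic nitrogen, which is the same change as that from compound 1 to compound 2, at the same kind of place.

The expectation for compound 4 rests on that single earlier step: because a number 7.9 percentage points higher from compound 1 to compound 2 (within the scatter) stayed small, the step of a number 4.1 percentage points higher from compound 3 to compound 4 (within the scatter) is expected to be small as well. On this basis compound 4 is estimated at 33% in this assay, with a range from 18% to 48%.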

Compound 4, a percentage reported as inhibition, at one concentration (the size of the read-out at that concentration, not a potency): -70.1%
Beside the measured number, compound 4's estimate is 103.1 percentage points above it; measured number below the stated range.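

In this assay, benzyl in place of cyclohexyl on an aromatic nitrogen does not carry over from one core to the other: the same change on two cores in this assay, a number 7.9 percentage points higher (within the scatter) from compound 1 to compound 2 and a number 99 percentage points lower (beyond the scatter) from compound 3 to compound 4, 106.9 percentage points apart, beyond the scatter of two such steps

The new step, a number 99 percentage points lower from compound 3 to compound 4 (beyond the scatter), is large, whereas the step on the other core, a number 7.9 percentage points higher from compound 1 to compound 2 (within the scatter), gives no guide to it. This does not show why the two cores part, nor whether the large step belongs to the benzyl group alone or to its pairing with the cyclohexyl that remains in compound 4; there is one pair on each core, so no general rule follows, and compound 4 gives -70.1% at a single concentration.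

The compounds shown leave open how the core of compound 3 responds to other groups on this nitrogen, such as methyl, phenethyl or a chain ending in an amine. They also leave open the result of benzyl on both aromatic nitrogens that carry cyclohexyl in compound 3.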